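Aryl swap on the ring nitrogen, carried to a second core

The source may hold more compounds than are shown below. What is called first, only, known or untested is meant among the compounds shown, and "the series" means these compounds.

Measured in a functional assay on MCF7 cells (Homo sapiens) for cytotoxicity, read by MTT assay, with a stated time of 24 h; a higher number here means a weaker inhibitor, a lower number a stronger inhibitor:
compound 1 `CCOc1ccccc1N1CCN(C(=S)SCc2nc3cc(Cl)c(Cl)cc3[nH]2)CC1`: 16200 nM
compound 2 `COc1ccc(N2CCN(C(=S)SCc3nc4cc(Cl)c(Cl)cc4[nH]3)CC2)cc1`: 19900 nM
compound 3 `COc1ccc(N2CCN(CCCSc3nc4ccccc4[nH]3)CC2)cc1`: 6840 nM

Compound 1 and compound 2 share one core; compound 3 carries another, and how the core of compound 3 differs from the core of compound 2 is not broken down here. Compound 3 has the lowest of the three numbers, and its gaps to compound 1 and to compound 2 both lie beyond the scatter, so among the measured compounds it is the strongest inhibitor in this assay.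

Within the first core, one change is seen: 2-ethoxyphenyl in place of 4-methoxyphenyl on an amine nitrogen in a ring. In this assay that change made a 1.2-fold lower number from compound 2 to compound 1 (0.09 log units; within the scatter), a step that does not rise above the scatter.

Compound 4 `CCOc1ccccc1N1CCN(CCCSc2nc3ccccc3[nH]2)CC1` is not yet measured. It stands to compound 3 as compound 1 stands to compound 2: 2-ethoxyphenyl in place of 4-methoxyphenyl on an amine nitrogen in a ring. The place is the same word for word in both pairs, so this is the same change on a different core.

The expectation for the step from compound 3 to compound 4 is a 1.2-fold lower number from compound 3 to compound 4 (0.07 log units; within the scatter), kept small because a 1.2-fold lower number from compound 2 to compound 1 (0.09 log units; within the scatter) was itself within the scatter. Within the data shown here, the single earlier instance gives no ground for a larger move in either direction. Compound 4 is therefore estimated at 5800 nM in this assay, with a likely range from 2500 nM to 14000 nM.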

Compound 4, half-maximal inhibitory concentration: 32700 nM
For compound 4 the middle estimate is 5.6-fold (0.75 log units) below the measured one; the measured number lies above the stated range.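

In this assay, 2-ethoxyphenyl in place of 4-methoxyphenyl on an amine nitrogen in a ring gave a 4.8-fold higher number from compound 3 to compound 4 (0.68 log units; beyond the scatter) and so weakened inhibition on the core of compound 3, whereas on the core of compound 1 the same change stayed within the scatter. The change therefore did not carry over unchanged from one core to the other, and its size on one core was no guide to its size on the other: the same change on two cores in this assay, a 1.2-fold lower number (0.09 log units; within the scatter) from compound 2 to compound 1 and a 4.8-fold higher number (0.68 log units; beyond the scatter) from compound 3 to compound 4, 5.9-fold (0.77 log units) apart, beyond the scatter of two such steps. Among these compounds, this rests on only two matched pairs, and it shows that the outcome of the change depended on the core in these pairs; it does not show which feature of the cores is responsible, why the steps differ, or how the change would behave on any further core.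

The swap alters the group and its place on the aromatic ring in one step, so the compounds shown leave open which of these accounts for the step on the core of compound 3. Also open, from the compounds shown here alone, is how a plain phenyl group on the ring nitrogen, or a longer chain on the core of compound 3, would stand.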